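Series notes: 2-methylphenyl for 3-chlorophenyl on the ring nitrogen

This account rests on a few compounds, and the source may have more. Where it says the series, first, only, none or still open, it means among the compounds named here.

Compound 1 `O=C1C(c2ccccc2)CC(c2ccccc2)C(=O)N1c1cccc(Cl)c1` gives 32.2% in a functional assay on the whole organism (strain Swiss albino) for inhibition, with Mus musculus as the target, in the maximal electroshock model, with a stated time of 2 h, at a dose of 25 mg/kg by the intraperitoneal route; a lower number here means less inhibition, a higher number more inhibition at the dose given (going by the name of the read-out). Compound 2 `Cc1ccccc1N1C(=O)C(c2ccccc2)CC(c2ccccc2)C1=O` gives 66.1% in this assay, and the step of a number 33.9 percentage points higher from compound 1 to compound 2 (beyond the scatter) accompanies the change (2-methylphenyl in place of 3-chlorophenyl on an amide-type nitrogen in a ring). Compound 3 `O=C1C(c2ccccc2Cl)CC(c2ccccc2Cl)C(=O)N1c1cccc(Cl)c1` gives 43.7% in this assay; the difference between the cores of compound 1 and compound 3 is not broken down here. Compound 4 `Cc1ccccc1N1C(=O)C(c2ccccc2Cl)CC(c2ccccc2Cl)C1=O` is not yet measured and differs from compound 3 by 2-methylphenyl in place of 3-chlorophenyl on an amide-type nitrogen in a ring, the same kind of change as that from compound 1 to compound 2, with the surroundings of the place differing in that the two ring atoms each bear a 2-chlorophenyl group rather than a phenyl group. On the strength of the step of a number 33.9 percentage points higher from compound 1 to compound 2 (beyond the scatter), a step of comparable size, a number 26.3 percentage points higher from compound 3 to compound 4 (beyond the scatter), is expected in this assay. Compound 4 is accordingly estimated at 70%, with an expected range from 50% to 90%. A single earlier instance supports this, so the range is kept wide.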

Compound 4, a percentage reported as inhibition, in the whole organism at one dose (the size of the read-out at that dose, not a potency): 60.6%
Compound 4: middle estimate off by 9.4 percentage points, on the high side, within the range that was stated.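

In this assay, 2-methylphenyl in place of 3-chlorophenyl on the amide-type nitrogen in a ring again goes with a higher number, a number 16.9 percentage points higher from compound 3 to compound 4 (beyond the scatter), so the direction of the step holds on both cores. The size of the step does not carry over unchanged: the same change on two cores in this assay, a number 33.9 percentage points higher (beyond the scatter) from compound 1 to compound 2 and a number 16.9 percentage points higher (beyond the scatter) from compound 3 to compound 4, 17 percentage points apart, beyond the scatter of two such steps Two cores show neither why the size differs nor how the change would behave on a further core.

Still open, as far as these compounds go, is how an alkyl amine, a carboxylic acid or a longer chain in place of the aryl group on that nitrogen would fare on either core. From the compounds shown here alone, whether the step holds at other doses or times also remains open.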